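Dropping the Bromobenzylsulfanyl Group from Compound 2

The source may report more compounds than this note shows. Statements on the series, on what has been measured and on what is new or still open speak of the compounds shown alone.

Compound 1, `Cc1cc(Nc2cc(-c3cccs3)[nH]n2)n2nc(SCc3ccc(Br)cc3)nc2n1`: 5370 nM
Compound 2, `Cc1cc(Nc2cc(-c3ccccc3)[nH]n2)n2nc(SCc3ccc(Br)cc3)nc2n1`: 2720 nM
Compound 3, `Cc1cc(Nc2cc(-c3ccc(Cl)cc3)[nH]n2)n2nc(SCc3ccc(Br)cc3)nc2n1`: 3620 nM

In a functional assay on MCF7 cells (Homo sapiens) for inhibition, read by MTT assay, with a stated time of 72 h (a lower number here means a stronger inhibitor, a higher number a weaker inhibitor), compound 2 gives 2720 nM. Compound 1 and compound 3 sit within the scatter of it, as the steps of a 2.0-fold lower number from compound 1 to compound 2 (0.30 log units; within the scatter) and a 1.3-fold higher number from compound 2 to compound 3 (0.12 log units; within the scatter) show, so the three compounds cannot be told apart. Compound 4, `Cc1cc(Nc2cc(-c3ccccc3)[nH]n2)n2ncnc2n1`, differs from compound 2 by hydrogen in place of (4-bromobenzyl)sulfanyl on an aromatic carbon. Among the compounds with values here, none of the measured steps touches this part of the shared core; all three, a 1.5-fold lower number from compound 1 to compound 3 (0.17 log units; within the scatter) included, vary the ring at the other end and stay within the scatter. Within the data shown here, the change to compound 4 thus has no measured step to rest on, and the estimate leans towards a higher number, the expected step being a 4.4-fold higher number from compound 2 to compound 4 (0.64 log units; beyond the scatter). Compound 4 is estimated at 12000 nM, with a range from 3000 nM to 50000 nM.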

Compound 4, half-maximal inhibitory concentration: > 50000 nM
Compound 4 gave a limit, no number; the forecaster's own chance of this, stated with the estimate: 30%; at least 4.1-fold (0.61 log units) between middle value and limit.
By their numbers in this assay, from the lowest: compounds 2, 3 and 1 (each within the scatter of the next). At a limit, above all of these: compound 4.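

Within the data shown here, replacing (4-bromobenzyl)sulfanyl with hydrogen, on the aromatic carbon between two ring nitrogen atoms, gives the first step here beyond the scatter: an at least 18-fold higher number from compound 2 to compound 4 (1.26 log units; beyond the scatter). In this assay compound 4 gives only a limit, not a number: > 50000 nM. The ring changes among compound 1, compound 2 and compound 3 all stayed within the scatter, so this position has the larger measured effect.

Going by these compounds, whether the sulfur, the benzyl ring or the bromine matters remains open, since the whole group left at once. Benzylsulfanyl, methylsulfanyl or an amine at this carbon could separate these parts.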